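Phenyl in Place of Propylaminomethyl: An Expected Cytotoxicity Value

The source may report more compounds than this note shows. Statements on the series, on what has been measured and on what is new or still open speak of the compounds shown alone.

The series opens with compound 1 `CCOC(=O)c1cc2sccc2n1Cc1ccc(OC)cc1`. In an ADME assay on HEK-293T cells (Homo sapiens) for cytotoxicity, read by luminescence, with a stated time of 24 h (on this read-out lower numbers stand for higher toxicity in this test and higher numbers for lower toxicity in this test), compound 1 reaches only a limit, > 100000 nM. Compound 2 `CCCNC(=O)C1CCN(C(=O)c2cc3sccc3n2Cc2ccc(OC)cc2)CC1` carries a larger amide side chain, and in this assay compound 2 gives 18800 nM. Compound 3 `CCCNCc1cc2c(cc(C(=O)N3CCC(C(=O)NCCC)CC3)n2Cc2ccc(OC)cc2)s1` adds a (propylamino)methyl group to the shared core of compound 2, and in this assay compound 3 again reaches only a limit, > 100000 nM. Among the compounds with values here, the single step that can be measured, an at least 5.3-fold higher number from compound 2 to compound 3 (0.72 log units; beyond the scatter), is bounded on one side by the limit of > 100000 nM in this assay, at which 2 of the 3 values shown sit. Within the data shown here, compound 3 therefore stands at the limit together with compound 1, while compound 2 is the only compound with a number.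

Compound 4 `CCCNC(=O)C1CCN(C(=O)c2cc3sc(-c4ccccc4)cc3n2Cc2ccc(OC)cc2)CC1` differs from compound 3 in one place: phenyl in place of (propylamino)methyl on an aromatic carbon. Among the measured compounds shown here, no measured step involves a phenyl, so the only guide is an at least 5.3-fold higher number from compound 2 to compound 3 (0.72 log units; beyond the scatter), which shows that a group on that carbon raised the number beyond the scatter. The phenyl is a different group, and compound 4 is expected to fall between the number of compound 2 and the limit, an estimated step of an at least 2.2-fold lower number from compound 3 to compound 4 (0.34 log units; beyond the scatter). The estimate for compound 4 in this assay is 45000 nM, within a range of 12000 nM to 100000 nM.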

Compound 4, half-maximal cytotoxic concentration: > 100000 nM
Compound 4: no number, only a limit (the forecaster's own chance of this, stated with the estimate: 40%); middle value at least 2.2-fold (0.34 log units) away from the limit.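

In this assay, phenyl in place of hydrogen on an aromatic carbon, next to the ring sulfur, gives an at least 5.3-fold higher number from compound 2 to compound 4 (0.72 log units; beyond the scatter). Two different groups on this carbon, the (propylamino)methyl of compound 3 and the phenyl of compound 4, now both move the read-out away from that of compound 2 in the same direction, even though the phenyl has one six-membered aromatic ring of carbon only and 0 hydrogen-bond donors, while the (propylamino)methyl has no ring and 1 hydrogen-bond donor. The step between compound 3 and compound 4 cannot be read, and the two groups cannot be ranked against each other, because both compounds stand at a limit: the limit of > 100000 nM in this assay, at which 3 of the 4 values shown sit.

The compounds shown leave open whether any group on this carbon would give a number rather than a limit, and so how large the change from hydrogen really is. They also leave open whether a small group such as methyl, a carboxylic acid or a shorter amine chain on the same carbon would shift the read-out from that of compound 2 as well.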